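The source may report more compounds than this note shows. Statements on the series, on what has been measured and on what is new or still open speak of the compounds shown alone.

Compound 1, whose structure is `N#Cc1c(-c2nnc(-c3nn(-c4ccccc4)c(-c4ccccc4)c3C#N)c3nn(-c4ccccc4)cc23)nn(-c2ccccc2)c1-c1ccccc1`, is the starting point of this small set. In a functional assay on IGROV-1 cells (Homo sapiens) for inhibition, read by sulforhodamine B assay, with a stated time of 48 h (a higher number here means a weaker inhibitor of growth, a lower number a stronger inhibitor of growth), compound 1 gives 13300 nM. Compound 2, `N#Cc1c(-c2nnc(-c3nn(-c4ccccc4)c(-c4ccccc4)c3C#N)c3nn(-c4ccc(Cl)cc4)cc23)nn(-c2ccccc2)c1-c1ccccc1`, carries the change (chloro in place of hydrogen on an aromatic carbon); in this assay compound 2 gives 98000 nM. The step of a 7.4-fold higher number from compound 1 to compound 2 (0.87 log units; beyond the scatter) is the only measured case of this change among the compounds shown.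

Compound 3, `N#Cc1c(-c2nnc(-c3ccccc3)c3nn(-c4ccccc4)cc23)nn(-c2ccccc2)c1-c1ccccc1`, has a different core; the difference between the two cores is not broken down here. In this assay compound 3 gives 94800 nM, which sits close to the value of compound 2 and is clearly weaker than that of compound 1.

Compound 4, `N#Cc1c(-c2nnc(-c3ccccc3)c3nn(-c4ccc(Cl)cc4)cc23)nn(-c2ccccc2)c1-c1ccccc1`, has not yet been measured. It stands to compound 3 as compound 2 stands to compound 1: the change chloro in place of hydrogen on an aromatic carbon is made at the same place, so it is the same change, repeated on the second core. Because the step of a 7.4-fold higher number from compound 1 to compound 2 (0.87 log units; beyond the scatter) pushed the number up on the first core, compound 4 is expected to follow in the same direction, with the estimated step of a 2.6-fold higher number from compound 3 to compound 4 (0.42 log units; beyond the scatter) from compound 3. Since compound 3 already gives a high number, the assay may well report only a limit for compound 4. The estimate for compound 4 in this assay is 250000 nM, expected to lie between 80000 nM and 700000 nM.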

Compound 4, concentration for 50% growth inhibition: 93400 nM
Compound 4: middle estimate off by 2.7-fold (0.43 log units), on the high side; the range from low to high includes it.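

In this assay, the change from phenyl to 4-chlorophenyl does not carry over from one core to the other: on the core of compound 3 it leaves the number unchanged, with a 1.0-fold lower number from compound 3 to compound 4 (0.01 log units; within the scatter), whereas on the core of compound 1 it gave a 7.4-fold higher number from compound 1 to compound 2 (0.87 log units; beyond the scatter). The two steps for this one change do not agree, and the gap between them is larger than repeated measurements would account for: the same change on two cores in this assay, a 7.4-fold higher number (0.87 log units; beyond the scatter) from compound 1 to compound 2 and a 1.0-fold lower number (0.01 log units; within the scatter) from compound 3 to compound 4, 7.5-fold (0.87 log units) apart, beyond the scatter of two such steps. This shows that, among these four compounds, the step seen on one core cannot be transferred to the other, but with a single pair on each core it does not show which part of the cores makes the difference, nor how the change would behave on any further core.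

The compounds shown carry only hydrogen or chloro at this place on the phenyl ring, so it remains open what a fluoro group, a methoxy group or an amine would do there on either core. As far as these compounds go, it also remains open whether the disagreement between the two steps would persist in growth measurements on other cell lines.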